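Cytotoxicity notes on one fused-core series

A few compounds are considered here, and "the series" means these few. Any claim that something is new, unique, unknown or untested is made for them only; others in the source may bear on it.

Measured so far in an ADME assay on MT4 cells (Homo sapiens) for cytotoxicity, read by MTT assay, with a stated time of 4 days; on this read-out higher numbers stand for lower toxicity in this test and lower numbers for higher toxicity in this test:
compound 1 `N#Cc1ccc(Nc2nc(Oc3ccc(Cl)cc3Cl)c3ccccc3n2)cc1`: 32000 nM
compound 2 `N#Cc1ccc(Nc2nc(Oc3ccc(Cl)cc3)c3ccccc3n2)cc1`: 198000 nM
compound 3 `Cc1cc(C#N)cc(C)c1Oc1nc(Nc2ccc(C#N)cc2)nc2ccccc12`: 203000 nM

Compound 3 differs from compound 2 by 4-cyano-2,6-dimethylphenyl in place of 4-chlorophenyl on an oxygen on an aromatic ring; the step is a 1.0-fold higher number from compound 2 to compound 3 (0.01 log units; within the scatter). Compound 1 differs from compound 2 by chloro in place of hydrogen on an aromatic carbon, and the step is a 6.2-fold lower number from compound 2 to compound 1 (0.79 log units; beyond the scatter).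

Compound 4 `Cc1cc(C#N)cc(C)c1Oc1nc(Nc2ccc(C#N)cc2)nc2ccc(Cl)cc12` differs from compound 3 by chloro in place of hydrogen on an aromatic carbon. This is the same kind of change as that from compound 2 to compound 1, not the same: there the chloro stands on a ring ortho to a large group and meta to a chloro group, whereas in compound 4 it stands on a ring that is part of a fused or bridged system of two rings, meta and para to a fused ring.

For the measured compounds named here, only one earlier instance of this kind of change is measured, and at a different place, so the expected step from compound 3 to compound 4 is a 2.3-fold lower number from compound 3 to compound 4 (0.35 log units; beyond the scatter), set smaller because a 6.2-fold lower number from compound 2 to compound 1 (0.79 log units; beyond the scatter) is a single step at another place and the only guide. Compound 4 is thus estimated at 90000 nM in this assay, expected between 25000 nM and 250000 nM.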

Compound 4, half-maximal cytotoxic concentration: 117000 nM
Estimate against measurement, compound 4: 1.3-fold (0.11 log units) below, and the stated range covers the measured number.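

In this assay, chloro in place of hydrogen on the shared core gives a 1.7-fold lower number from compound 3 to compound 4 (0.24 log units; within the scatter), so this step cannot be told from the usual scatter. The size of the step does not carry over from one case to the other: the same change on two cores in this assay, a 6.2-fold lower number (0.79 log units; beyond the scatter) from compound 2 to compound 1 and a 1.7-fold lower number (0.24 log units; within the scatter) from compound 3 to compound 4, 3.6-fold (0.55 log units) apart, beyond the scatter of two such steps

These two steps do not show whether the gap follows the place of the chloro or the rest of the molecule, as the two pairs differ in both. Open, from the compounds shown here alone, is what chloro at the place it holds in compound 4 would do with 4-chlorophenyl on the oxygen. Also open, going by these compounds, is whether fluoro, methoxy or an amine at that place would behave as chloro does.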